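A few compounds are considered here, and "the series" means these few. Any claim that something is new, unique, unknown or untested is made for them only; others in the source may bear on it.

Compound 1 `COc1ccc2c(=O)c(/C=C/C(=O)Nc3cc(C)ccc3C)coc2c1` gives 58400 nM in a functional assay on HeLa cells (Homo sapiens) for inhibition, read by MTT assay, with a stated time of 48 h; a lower number here means a stronger inhibitor, a higher number a weaker inhibitor.
Compound 2 `COc1ccc2c(=O)c(/C=C/C(=O)NCc3ccc(F)cc3)coc2c1` gives > 100000 nM in this assay, which is a limit of the assay and not a number.

Compound 2 therefore stands at the edge of what this assay reports, and nothing more precise is known of it; it is one of the values that sit at the limit of > 100000 nM in this assay, at which 1 of the 2 values shown sits. Going by the values given here, the only measured step is an at least 1.7-fold higher number from compound 1 to compound 2 (0.23 log units; that floor lies within the scatter), and its floor lies within the scatter, so the true size of that step is not known.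

Compound 3 `COc1ccc2c(=O)c(/C=C/C(=O)Nc3ccccc3C)coc2c1` differs from compound 2 by 2-methylphenyl in place of 4-fluorobenzyl on an amide-type nitrogen. This change runs the opposite way from the measured step: it takes the amide nitrogen back from a benzyl-type group to an aryl group, close to what compound 1 carries. Since the measured step gives only a floor that lies within the scatter, compound 3 is expected to move toward a lower number than compound 2, by a step of an at least 1.4-fold lower number from compound 2 to compound 3 (0.15 log units; that floor lies within the scatter), which may itself lie within the scatter. Compound 3 is estimated at 70000 nM, between 25000 nM and 200000 nM, with a fair chance that this assay again reports only a limit.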

Compound 3, half-maximal inhibitory concentration: 7270 nM
For compound 3 the middle estimate is 9.6-fold (0.98 log units) above the measured one, outside the stated range (below it).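

In this assay, 2-methylphenyl in place of 4-fluorobenzyl on the amide-type nitrogen gives an at least 13-fold lower number from compound 2 to compound 3 (1.13 log units; beyond the scatter), so the group at this position can shift the read-out well beyond the scatter, which the floor of the earlier step could not show. The aryl group itself also proves sensitive to a small change, as hydrogen in place of methyl on an aromatic carbon gives an 8.0-fold lower number from compound 1 to compound 3 (0.90 log units; beyond the scatter), and 2-methylphenyl and 2,5-dimethylphenyl therefore cannot be treated as interchangeable here. The true size of the first of these steps remains unknown, since the value of compound 2 is a limit of the assay and not a number: the limit of > 100000 nM in this assay, at which 1 of the 3 values shown sits.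

The step from compound 2 to compound 3 exchanges the link to the ring and the ring's substituent together, so the compounds shown do not separate what each contributes. They also leave open how an unsubstituted benzyl, a 2-methoxyphenyl or a 2-chlorophenyl on the same nitrogen would read in this assay.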